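The source may report more compounds than this note shows. Statements on the series, on what has been measured and on what is new or still open speak of the compounds shown alone.

Three compounds that share one core were tested in a functional assay on JAR cells (Homo sapiens) for inhibition, read by MTT assay, with a stated time of 72 h, tested at 10 uM; a higher number here means more inhibition at the concentration tested (going by the name of the read-out), a lower number less inhibition. Compound 1 `CCOC(=O)C1=C(Nc2ccc(F)cc2)S/C(=C\c2ccc[nH]2)C1=O` gives 61.5%. Compound 2 `CCOC(=O)C1=C(Nc2cccc(F)c2)S/C(=C\c2ccc[nH]2)C1=O` gives 45.4%, and compound 3 `CCOC(=O)C1=C(Nc2ccc(C(F)(F)F)cc2)S/C(=C\c2ccc[nH]2)C1=O` gives 38.5%. Compound 2 differs from compound 1 by 3-fluorophenyl in place of 4-fluorophenyl on an amine nitrogen, a step of a number 16.1 percentage points lower from compound 1 to compound 2 (beyond the scatter). Compound 3 differs from compound 1 by trifluoromethyl in place of fluoro on an aromatic carbon, a step of a number 23 percentage points lower from compound 1 to compound 3 (beyond the scatter). Compound 4 `CCOC(=O)C1=C(Nc2cccc(C(F)(F)F)c2)S/C(=C\c2ccc[nH]2)C1=O` is not yet measured; it differs from compound 2 by trifluoromethyl in place of fluoro on an aromatic carbon. This is the same kind of change as that from compound 1 to compound 3, though there the new group sits para to a large group and here it sits meta to a large group. Because of a number 23 percentage points lower from compound 1 to compound 3 (beyond the scatter) a comparable loss is expected for compound 4, estimated as a number 17.4 percentage points lower from compound 2 to compound 4 (beyond the scatter). Compound 4 is therefore expected near 28%, between 12% and 44%.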

Compound 4, a percentage reported as inhibition, at one concentration (the size of the read-out at that concentration, not a potency): 52.9%
For compound 4 the middle estimate is 24.9 percentage points below the measured one; the whole stated range lies below it.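

Trifluoromethyl in place of fluoro in this assay gives a number 7.5 percentage points higher from compound 2 to compound 4 (within the scatter) and so no change that can be told from the scatter on this core. The loss seen on the core of compound 1 does not carry over to the core of compound 2, and the two steps clearly differ: the same change on two cores in this assay, a number 23 percentage points lower (beyond the scatter) from compound 1 to compound 3 and a number 7.5 percentage points higher (within the scatter) from compound 2 to compound 4, 30.5 percentage points apart, beyond the scatter of two such steps.
This shows that the result of this change cannot simply be moved from one core to the other in this series, but with only these two steps it gives neither a reason nor a general rule.

Still open, from the compounds shown here alone, is how other groups in the same place, such as chloro, methoxy or a nitrile, would behave. Also open, going by these compounds, is whether either step would hold if the ethyl ester were replaced by a carboxylic acid.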